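The source may report more compounds than this note shows. Statements on the series, on what has been measured and on what is new or still open speak of the compounds shown alone.

Measured so far in an assay on Cerebral cortex for binding affinity to adenosine receptor A1 (Cavia porcellus), read by radioligand binding; a higher number here means a weaker inhibitor, a lower number a stronger inhibitor:
compound 1, `CCCn1c(=O)n(CCN(C)C)c(=O)c2[nH]cnc21`: 4300 nM
compound 2, `CCCn1c(=O)n(CCCOC)c(=O)c2[nH]cnc21`: 12400 nM
compound 3, `C=CCCn1cnc2c1c(=O)n(C)c(=O)n2CCC`: 6000 nM

Compound 3 stands second highest of the three numbers; its gap to compound 1 lies within the scatter, and only the gap to compound 2 lies beyond it. Compound 4, `CCCn1c(=O)n(C)c(=O)c2c1ncn2CCO`, differs from compound 3 by hydroxy in place of vinyl on a saturated chain carbon, two bonds along the chain from an aromatic nitrogen. Among the measured compounds shown here, the one measured step that touches a chain substituent at such a place is a 2.9-fold higher number from compound 1 to compound 2 (0.46 log units; beyond the scatter), a modest shift. For the measured compounds named here, no measured pair covers a vinyl-to-hydroxy exchange, so the direction is open; a step of at most modest size is expected in this assay, no change at the digits printed from compound 3 to compound 4 (within the scatter). Compound 4 is therefore estimated at 6000 nM in this assay, within 2500 nM to 15000 nM.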

Compound 4, inhibition constant: 41400 nM
Beside the measured number, compound 4's estimate is 6.9-fold (0.84 log units) below it; measured number outside the range, above it.
By their numbers in this assay, from the lowest: compounds 1 and 3 (each within the scatter of the next); then compound 2; then compound 4.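

In this assay, among the compounds shown here, this chain position is sensitive to the exchange: hydroxy in place of vinyl gives a 6.9-fold higher number from compound 3 to compound 4 (0.84 log units; beyond the scatter) and so settles the direction, which the earlier compounds left open, towards a weaker inhibitor. The same change also reads but-3-en-1-yl to 2-hydroxyethyl, so the shorter chain and the hydroxy are not separated here. No available evidence gives a reason for this shift.

As far as these compounds go, whether the hydroxy itself or the loss of the vinyl drives the rise stays open. A methoxy, a carboxylic acid or a longer chain ending in hydroxy at this place would help to separate these readings.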